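This account rests on a few compounds, and the source may have more. Where it says the series, first, only, none or still open, it means among the compounds named here.

Compound 1 `Cc1ccc(CN2CCC(CCN(Cc3ccc(-c4ccc(F)cc4)cc3)C(=O)NC(C)C)CC2)cc1`: 113%
Compound 2 `CC(=O)OCC(C)(C)NC(=O)N(CCC1CCN(Cc2ccc(C)cc2)CC1)Cc1ccc(-c2ccc(F)cc2)cc1`: 92.3%
Compound 3 `CC(=O)OCC(C)(C)NC(=O)N(CCC1CCN(Cc2ccc(C)cc2)CC1)Cc1ccc(-c2ccccc2)cc1`: 102%

In an in vitro functional assay on HEK293 cells for antagonist activity at melanin-concentrating hormone receptor 1 (Homo sapiens) (on this read-out higher numbers stand for larger maximal responses and lower numbers for smaller maximal responses), compound 2 stands lowest of the three measured compounds. Compound 3 lies within the scatter of it, whereas the step of a number 20.7 percentage points lower from compound 1 to compound 2 (beyond the scatter) is beyond the scatter, so compound 1 sits clearly higher.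

Compound 4 `Cc1ccc(CN2CCC(CCN(Cc3ccc(-c4ccc(F)cc4)cc3)C(=O)NC(C)(C)CO)CC2)cc1` differs from compound 2 in one place: hydrogen in place of acetyl on an oxygen on a saturated carbon. Of the measured steps, only a number 20.7 percentage points lower from compound 1 to compound 2 (beyond the scatter) touches this part of the molecule, where acetoxymethyl in place of hydrogen went with a lower response. The step of a number 9.7 percentage points higher from compound 2 to compound 3 (within the scatter) concerns fluoro on an aromatic carbon elsewhere and bears little here. Since compound 4 keeps part of what entered in that step, the value for compound 4 is expected to move only modestly back toward compound 1, by about a number 7.7 percentage points higher from compound 2 to compound 4 (within the scatter). The estimate for compound 4 is 100%, with a range from 85% to 115%.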

Compound 4, largest response reached (reported as Imax), in percent of the reference or control that the assay uses: 102%
Estimate against measurement, compound 4: 2 percentage points below; low and high end bracket the measured number.
By their numbers in this assay, from the lowest: compounds 2, 3 and 4 (each within the scatter of the next); then compound 1.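

In this assay, changing acetoxymethyl to hydroxymethyl gives a number 9.7 percentage points higher from compound 2 to compound 4 (within the scatter), so at this position the acetyl makes no change that can be told from scatter. Hydroxymethyl in place of hydrogen on the same carbon still gives a number 11 percentage points lower from compound 1 to compound 4 (beyond the scatter), which shows that a modest drop in response remains without any acetyl. Nothing measured here explains either step.

Going by these compounds, whether an aminomethyl or a carboxylic acid at this place would give a similar response remains open. So does whether a longer chain carrying the hydroxy would narrow the gap to the unsubstituted chain.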